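The source may report more compounds than this note shows. Statements on the series, on what has been measured and on what is new or still open speak of the compounds shown alone.

Compound 2 `COc1ccc(F)cc1CNCCCNc1ccnc2cc(CCc3ccccc3)ccc12` gives 23 10^-6 cm/s in an ADME assay for permeability, using PAMPA, with a stated time of 30 min, at pH 7.4; on this read-out lower numbers stand for lower permeability and higher numbers for higher permeability. Among the compounds with values here, on the three numbers seen so far compound 2 stands level, at the digits printed, with compound 3 `c1ccc(CCc2ccc3c(NCCCNCc4ccco4)ccnc3c2)cc1`, which gives 23 10^-6 cm/s in this assay, and the two sit together at the bottom; the only higher number belongs to compound 1 `Fc1ccc(Oc2ccc3c(NCCCNCc4ccco4)ccnc3c2)cc1`, which gives 317 10^-6 cm/s in this assay.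

The new compound 4 `COc1ccc(F)cc1CNCCCNc1ccnc2cc(-c3ccc(C(F)(F)F)cc3)ccc12` differs from compound 2 in one place: 4-(trifluoromethyl)phenyl in place of phenethyl on an aromatic carbon.

Two measured steps speak to this. The step of no change at the digits printed from compound 2 to compound 3 (within the scatter) changes the other end of the molecule and leaves the number alone, so the end carrying the phenethyl group is the one that has moved the read-out. There, the step of a 14-fold lower number from compound 1 to compound 3 (1.14 log units; beyond the scatter) shows that swapping the group on that aromatic carbon can shift the number a long way, with phenethyl giving the lower value. Compound 4 puts a fluorinated aromatic group back in that place, as compound 1 has. Within the data shown here, a rise from compound 2 is therefore expected, though with no exact precedent for this group the size is uncertain, and the expected step is a 3.0-fold higher number from compound 2 to compound 4 (0.48 log units; beyond the scatter). For compound 4 the estimate in this assay is 70 10^-6 cm/s, with a range from 18 10^-6 cm/s to 280 10^-6 cm/s.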

Compound 4, apparent permeability: 237 10^-6 cm/s
The estimate for compound 4 lay 3.4-fold (0.53 log units) below the measured number; low and high end bracket the measured number.
By their numbers in this assay, from the lowest: compounds 2 and 3 (each within the scatter of the next); then compounds 4 and 1 (each within the scatter of the next).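

The step of a 10-fold higher number from compound 2 to compound 4 (1.01 log units; beyond the scatter) shows that in this assay this aromatic carbon can move the number by a large margin with the 5-fluoro-2-methoxyphenyl end in place, whereas the earlier large step at this position, a 14-fold lower number from compound 1 to compound 3 (1.14 log units; beyond the scatter), had the furan-2-yl end. In both of these single-place pairs phenethyl carries the lower number, and neither pair goes against that, although the groups replacing it differ. The change also leaves the counts of six-membered aromatic rings, hydrogen-bond donors, hydrogen-bond acceptors and net charge as they were, so those counts do not separate the two groups, and no measurement shown here gives a cause for the step.

The compounds shown leave open whether the trifluoromethyl group matters, or whether removing the chain of phenethyl would give a similar rise, which a plain phenyl group or a phenyl group carrying a nitrile or a carboxylic acid at that ring position could help to separate. They also leave open how 4-(trifluoromethyl)phenyl behaves with the furan-2-yl end.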